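This account rests on a few compounds, and the source may have more. Where it says the series, first, only, none or still open, it means among the compounds named here.

Going by the values given here, compound 2 `CN1CCC(N(C)C(=O)C2CN(S(=O)(=O)c3cccc4ccccc34)c3ccccc32)CC1` gives 31.6 nM in a functional assay on CHO cells for antagonist activity at 5-hydroxytryptamine receptor 6 (Homo sapiens), read by FLIPR (a lower number here means a stronger inhibitor, a higher number a weaker inhibitor), the higher of the two numbers so far; its nearest neighbour is compound 1 `CN1CCC(N(C)C(=O)C2CN(S(=O)(=O)c3cccc4c(Cl)cccc34)c3ccccc32)CC1`, which gives 5.01 nM, and the step of a 6.3-fold higher number from compound 1 to compound 2 (0.80 log units; beyond the scatter) comes from a hydrogen in place of chloro on an aromatic carbon. Compound 3 `CN1CCC(N(C)C(=O)C2CN(S(=O)(=O)c3ccc4ccccc4c3)c3ccccc32)CC1` differs from compound 2 by naphthalen-2-yl in place of naphthalen-1-yl on a sulfonyl sulfur. Among the compounds with values here, no measured step bears on this change, since the only step known alters a substituent rather than the point of attachment; the account therefore expects no step beyond the scatter, a 1.3-fold higher number from compound 2 to compound 3 (0.10 log units; within the scatter). Compound 3 is expected to give 40 nM, between 12 nM and 130 nM.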

Compound 3, inhibition constant: 25.1 nM
Estimate against measurement, compound 3: 1.6-fold (0.20 log units) above, within the range that was stated.
By their numbers in this assay, from the lowest: compound 1; then compounds 3 and 2 (each within the scatter of the next).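

In this assay, naphthalen-2-yl in place of naphthalen-1-yl on the sulfonyl sulfur gives a step within the scatter (a 1.3-fold lower number from compound 2 to compound 3 (0.10 log units; within the scatter)), so the point of attachment does not separate these two compounds. Set against the 5-chloronaphthalen-1-yl group, naphthalen-2-yl gives a step beyond the scatter (a 5.0-fold higher number from compound 1 to compound 3 (0.70 log units; beyond the scatter)), much as hydrogen in place of chloro does. Nothing available here explains either step. On these data alone, it remains open whether a chloro on naphthalen-2-yl would lower the number likewise, and whether fluoro, methoxy or an amine could stand in place of chloro.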